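This account rests on a few compounds, and the source may have more. Where it says the series, first, only, none or still open, it means among the compounds named here.

Measured so far:
compound 1, `CN(O)/C=C\C(=O)c1ccc(Cl)cc1` — 550 nM
compound 2, `O=C(/C=C\N(O)Cc1ccccc1)c1ccc([N+](=O)[O-])cc1` — 2500 nM
compound 3, `CC(=O)ON(/C=C\C(=O)c1ccc(Cl)cc1)Cc1ccccc1` — > 25000 nM

In an assay on RBL-1 cells for inhibition of Polyunsaturated fatty acid 5-lipoxygenase (Rattus norvegicus) (a higher number here means a weaker inhibitor, a lower number a stronger inhibitor), compound 3 gives only a limit, > 25000 nM, and no number; it sits at the limit of > 25000 nM in this assay, at which 1 of the 3 values shown sits. Compound 1 gives 550 nM and compound 2 gives 2500 nM in this assay. Compound 4, `O=C(/C=C\N(O)Cc1ccccc1)c1ccc(Cl)cc1`, differs from compound 3 by hydrogen in place of acetyl on an oxygen. Compound 1 and compound 2 both carry hydrogen on that oxygen, and their values are the ground for the expectation: compound 1 gives 550 nM, and compound 2 gives 2500 nM. Compound 4 is therefore expected to gain strongly, with an estimated step of an at least 20-fold lower number from compound 3 to compound 4 (1.31 log units; beyond the scatter). The estimate for compound 4 is 1200 nM, in a range from 300 nM to 5000 nM.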

Compound 4, half-maximal inhibitory concentration: 1500 nM
Beside the measured number, compound 4's estimate is 1.3-fold (0.10 log units) below it; the measured number falls inside the stated range.
By their numbers in this assay, from the lowest: compound 1; then compounds 4 and 2 (each within the scatter of the next). At a limit, above all of these: compound 3.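

In this assay, going by these compounds alone, acetoxy to hydroxy on the oxygen bound to the amine nitrogen gives an at least 16-fold lower number from compound 3 to compound 4 (1.22 log units; beyond the scatter), the first comparison at this oxygen with the rest of the structure unchanged. Compound 3 gives only a limit, not a number: the limit of > 25000 nM in this assay, at which 1 of the 4 values shown sits. Elsewhere, chloro in place of nitro on an aromatic carbon gives a 1.7-fold lower number from compound 2 to compound 4 (0.22 log units; within the scatter), and phenyl in place of hydrogen on a saturated chain carbon bound to an amine nitrogen gives a 2.7-fold higher number from compound 1 to compound 4 (0.44 log units; beyond the scatter). The compounds shown leave open whether a methyl or a benzoyl on that oxygen would match acetyl. From the compounds shown here alone, the full size of the acetoxy to hydroxy step also stays open.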